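A few compounds are considered here, and "the series" means these few. Any claim that something is new, unique, unknown or untested is made for them only; others in the source may bear on it.

Two members of one series have been examined in a functional assay on the whole organism for inhibition, with Rattus norvegicus as the target, with a stated time of 1 h, at a dose of 25 mg/kg by the oral route; a higher number here means more inhibition at the dose given (going by the name of the read-out), a lower number less inhibition. Compound 1, `CC1(C)OC(c2ccc(C(F)(F)F)cc2)=CC1=O`, gives 39% in this assay. Compound 2, `CC1(C)OC(c2ccc(Cl)cc2)=CC1=O`, gives 29% in this assay. Among the measured compounds shown here, the only measured step connecting them, a number 10 percentage points lower from compound 1 to compound 2 (within the scatter), involves chloro in place of trifluoromethyl on an aromatic carbon. Among the two numbers available, compound 2 stands lowest, with compound 1 as its nearest neighbour at a value within the scatter, so no ordering between the two can be claimed.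

Compound 3, `CC1(C)OC(c2ccc(Br)cc2)=CC1=O`, has not yet been measured in this assay. It differs from compound 2 as follows: bromo in place of chloro on an aromatic carbon. For the measured compounds named here, no measured step involves bromo, and the one measured step that touches the same aromatic carbon lay within the scatter. A swap of one halogen for another at this place is therefore expected to leave the inhibition near that of compound 2, with no step beyond the scatter in either direction. The expected step is a number 3 percentage points higher from compound 2 to compound 3 (within the scatter). For compound 3 the estimate is 32%, within a range from 15% to 50%.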

Compound 3, a percentage reported as inhibition, in the whole organism at one dose (the size of the read-out at that dose, not a potency): 36%
Beside the measured number, compound 3's estimate is 4 percentage points below it; low and high end bracket the measured number.
By their numbers in this assay, from the lowest: compounds 2, 3 and 1 (each within the scatter of the next).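

In this assay, the exchange of one halogen for another at this aromatic carbon gives a number 7 percentage points higher from compound 2 to compound 3 (within the scatter), while the exchange of trifluoromethyl for bromo gives a number 3 percentage points lower from compound 1 to compound 3 (within the scatter). Among the compounds shown here, the earlier compounds offered only one step at this place, whereas chloro, bromo and trifluoromethyl are now joined by steps that all lie within the scatter, so at this single oral dose the read-out does not separate these three groups and gives them no order. No supporting evidence is available to explain this lack of separation.

What the compounds shown leave open is whether any group of a different kind on this aromatic carbon, such as an amine, a carboxylic acid or a methoxy group, would move the inhibition beyond the scatter in either direction. They also leave open whether the three groups would still be indistinguishable at other doses, since each number gives the size of the inhibition at one dose and not a potency, and whether a change elsewhere on the shared core would matter more than one at this place.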